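Chloro on the pendant ring in two pyrazole sulfonyl cores

The source may hold more compounds than are shown below. What is called first, only, known or untested is meant among the compounds shown, and "the series" means these compounds.

Two cores are compared in a functional assay on cells (Melanoma cell, Homo sapiens) for cytotoxicity, read by sulforhodamine B assay, with a stated time of 48 h; a higher number here means a weaker inhibitor of growth, a lower number a stronger inhibitor of growth. The first is that of compound 1 `COc1ccc(OC)c(-c2cc(-c3ccccc3)nn2-c2ccc(S(=O)(=O)NC(C)=O)cc2)c1`, which gives 36200 nM; compound 2 `COc1ccc(OC)c(-c2cc(-c3ccc(Cl)cc3)nn2-c2ccc(S(=O)(=O)NC(C)=O)cc2)c1` carries the same core with a change of chloro in place of hydrogen on an aromatic carbon, and gives 28700 nM. The step of a 1.3-fold lower number from compound 1 to compound 2 (0.10 log units; within the scatter) is therefore small and within the usual scatter of the measurement. The second core is that of compound 3 `NS(=O)(=O)c1ccc(-n2nc(-c3ccccc3)cc2-c2cc(O)ccc2O)cc1`, which gives 92000 nM; the difference between the two cores is not broken down here, and its value stands beyond the scatter from both compound 1 and compound 2.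

Compound 4 `NS(=O)(=O)c1ccc(-n2nc(-c3ccc(Cl)cc3)cc2-c2cc(O)ccc2O)cc1` is not yet measured. It differs from compound 3 by chloro in place of hydrogen on an aromatic carbon, which is the same change as that from compound 1 to compound 2, made at the same kind of place on the pendant ring. Because the step of a 1.3-fold lower number from compound 1 to compound 2 (0.10 log units; within the scatter) was within the scatter, the step of a 1.3-fold lower number from compound 3 to compound 4 (0.11 log units; within the scatter) is expected to be of a similar small size in this assay, resting on a single earlier pair. Compound 4 is therefore estimated at 72000 nM, with a likely range from 35000 nM to 150000 nM.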

Compound 4, concentration for total growth inhibition: 38900 nM
For compound 4 the middle estimate is 1.9-fold (0.27 log units) above the measured one, within the range that was stated.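

In this assay, the change from phenyl to 4-chlorophenyl on the core of compound 3 gives a 2.4-fold lower number from compound 3 to compound 4 (0.37 log units; beyond the scatter). Set beside the same change on the core of compound 1, this step does not differ from the earlier one by more than the scatter allows: the same change on two cores in this assay, a 1.3-fold lower number (0.10 log units; within the scatter) from compound 1 to compound 2 and a 2.4-fold lower number (0.37 log units; beyond the scatter) from compound 3 to compound 4, 1.9-fold (0.27 log units) apart, within the scatter of two such steps The two pairs are therefore compatible with a single shared step across these cores, but they do not show that the chloro counts for more on the core of compound 3, and one pair per core cannot fix the size of any shared step.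

Open questions are whether a fluoro, a methyl or a methoxy group at the same place on the pendant ring would follow the chloro, and whether an amine there would do the same. Also open, as far as these compounds go, is which difference between the cores matters, the acetyl group on the sulfonamide nitrogen or the methoxy groups against the hydroxy groups.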